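From 3-methylphenyl to 2-vinylphenyl on the shared core

This account rests on a few compounds, and the source may have more. Where it says the series, first, only, none or still open, it means among the compounds named here.

In a functional assay (muscle tissue) with Cavia porcellus as the target (on this read-out higher numbers stand for an effect only at larger amounts of compound and lower numbers for an effect already at smaller amounts), compound 1 `COC(=O)C1=C(C)N=C(C)/C(=C(\O)OC)C1c1cccc(OC)c1` gives 191 nM, compound 2 `COC(=O)C1=C(C)N=C(C)/C(=C(\O)OC)C1c1ccccc1OC` gives 57.5 nM and compound 3 `COC(=O)C1=C(C)N=C(C)/C(=C(\O)OC)C1c1cccc(C)c1` gives 110 nM. Compound 3 stands within the scatter of both others, with a 1.7-fold lower number from compound 1 to compound 3 (0.24 log units; within the scatter) and a 1.9-fold higher number from compound 2 to compound 3 (0.28 log units; within the scatter). Compound 4 `C=Cc1ccccc1C1C(C(=O)OC)=C(C)N=C(C)/C1=C(\O)OC` carries 2-vinylphenyl in place of 3-methylphenyl on a saturated ring carbon. The nearest guide is a single pair, 2-methoxyphenyl in place of 3-methoxyphenyl, with a 3.3-fold lower number from compound 1 to compound 2 (0.52 log units; beyond the scatter). No vinyl group has been measured, so only a modest move towards lower numbers in this assay is expected, namely a 2.2-fold lower number from compound 3 to compound 4 (0.34 log units; beyond the scatter). For compound 4 the estimated value is 50 nM, with an expected range from 18 nM to 140 nM.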

Compound 4, half-maximal effective concentration: 4.47 nM
Estimate against measurement, compound 4: 11-fold (1.05 log units) above, outside the stated range (below it).
By their numbers in this assay, from the lowest: compound 4; then compounds 2, 3 and 1 (each within the scatter of the next, the first and the last beyond it).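

In this assay, within the data shown here, the group on the saturated ring carbon can shift the number far more than the earlier compounds showed, with a 25-fold lower number from compound 3 to compound 4 (1.39 log units; beyond the scatter) when 2-vinylphenyl replaces 3-methylphenyl. Exchanging the methoxy group for a vinyl group gives a 13-fold lower number from compound 2 to compound 4 (1.11 log units; beyond the scatter) and the widest gap in the set is a 43-fold lower number from compound 1 to compound 4 (1.63 log units; beyond the scatter) so compound 4 has the lowest number, beyond the scatter of every other compound. From the compounds shown here alone, whether an ethyl or an ethynyl group in the same place would keep this low number stays open. Nothing at hand accounts for the size of these steps.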